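A few compounds are considered here, and "the series" means these few. Any claim that something is new, unique, unknown or untested is made for them only; others in the source may bear on it.

Among the compounds with values here, compound 3, `CCN(Cc1ccccc1)c1cc(C)nc(N(CC)c2ccc(C(C)C)cc2Br)n1`, holds the lowest of the two numbers so far reported in an assay on isolated protein for binding affinity to corticotropin-releasing factor receptor 1 (Homo sapiens) (a higher number here means a weaker inhibitor, a lower number a stronger inhibitor), where compound 3 gives 17 nM. Its nearest neighbour is compound 2, `CCN(c1nc(C)cc(N2CCCCC2)n1)c1ccc(C(C)C)cc1Br`, which in this assay gives 29 nM; the step of a 1.7-fold lower number from compound 2 to compound 3 (0.23 log units; within the scatter) stays within the scatter, so the two compounds cannot be told apart. Compound 1, `CCN(c1nc(C)cc(C)n1)c1ccc(C(C)(C)C)cc1Br`, gives in this assay only a limit, > 100 nM, and no number; this is the limit of > 100 nM in this assay, at which 1 of the 3 values shown sits.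

Compound 4, `CCCN(CC1CC1)c1cc(C)nc(N(CC)c2ccc(C(C)C)cc2Br)n1`, has not yet been measured in this assay. It differs from compound 3 in one place: (cyclopropylmethyl)(propyl)amino in place of benzyl(ethyl)amino on an aromatic carbon. Within the data shown here, the single measured step that bears on this position is a 1.7-fold lower number from compound 2 to compound 3 (0.23 log units; within the scatter), in which one amino group replaced another on the same aromatic carbon and the number barely moved. On that evidence, a further exchange of amino groups at the same place is expected to produce no step beyond the scatter, in either direction. Compound 4 is therefore estimated to give 22 nM in this assay, with a likely range from 7 nM to 70 nM. This estimate corresponds to an expected step of a 1.3-fold higher number from compound 3 to compound 4 (0.11 log units; within the scatter).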

Compound 4, inhibition constant: 9 nM
Compound 4: middle estimate off by 2.4-fold (0.39 log units), on the high side; low and high end bracket the measured number.
By their numbers in this assay, from the lowest: compounds 4, 3 and 2 (each within the scatter of the next, the first and the last beyond it). At a limit, above all of these: compound 1.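

In this assay, the position on this aromatic carbon tolerates the loss of the six-membered aromatic ring of the benzyl(ethyl)amino group: putting (cyclopropylmethyl)(propyl)amino in its place gives a 1.9-fold lower number from compound 3 to compound 4 (0.28 log units; within the scatter). The same position also shows its first step beyond the scatter, though a modest one, when (cyclopropylmethyl)(propyl)amino replaces piperidin-1-yl, with a 3.2-fold lower number from compound 2 to compound 4 (0.51 log units; beyond the scatter); compound 3 lies within the scatter of both, so only compound 2 and compound 4 can be told apart. Nothing measured here accounts for either step.

Going by these compounds, whether a longer chain on the amine, as in dibutylamino, would keep this level of binding remains open. So does the effect of a ring amine carrying a second heteroatom, such as morpholin-4-yl, at this place.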